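The source may hold more compounds than are shown below. What is called first, only, known or untested is meant among the compounds shown, and "the series" means these compounds.

In a functional assay on the whole organism (strain Kunming) with Mus musculus as the target, with a stated time of 0.5 h, at a dose of 100 mg/kg by the intraperitoneal route (on this read-out higher numbers stand for a weaker effect at the one dose given and lower numbers for a stronger effect), compound 1 `COc1ccccc1/C=C/C(=O)OC/C=C/c1cc(OC)c(OC)cc1OC` gives 100%, compound 2 `COc1cc(OC)c(OC)cc1/C=C/COC(=O)/C=C/c1ccc(F)cc1` gives 100%, and compound 3 `COc1cc(OC)c(OC)cc1/C=C/COC(=O)/C=C/c1cccc(Br)c1` gives 100%; compound 3 thus stands level with both of the others at the digits given. The steps of no change at the digits printed from compound 1 to compound 2 (within the scatter), no change at the digits printed from compound 1 to compound 3 (within the scatter) and no change at the digits printed from compound 2 to compound 3 (within the scatter) each exchange one substituted phenyl for another on a double-bonded chain carbon bound to a double-bonded chain carbon, and none of them moved the read-out beyond the scatter. Compound 4 `COc1cc(OC)c(OC)cc1/C=C/COC(=O)/C=C/c1ccc(Cl)cc1` differs from compound 3 in the same manner: 4-chlorophenyl in place of 3-bromophenyl on a double-bonded chain carbon bound to a double-bonded chain carbon. Because the steps of no change at the digits printed from compound 1 to compound 2 (within the scatter), no change at the digits printed from compound 1 to compound 3 (within the scatter) and no change at the digits printed from compound 2 to compound 3 (within the scatter) each left the value unchanged, the step of no change at the digits printed from compound 3 to compound 4 (within the scatter) is expected to be none beyond the scatter. Compound 4 is therefore estimated at 100%, with a range from 85% to 100%.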

Compound 4, a percentage reported as activity, at one dose (the size of the read-out at that dose, not a potency): 100%
The estimate for compound 4 equals the measured number at the digits printed; the range from low to high includes it.
By their numbers in this assay, from the lowest: compounds 1, 2, 3 and 4 (each within the scatter of the next).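

In this assay the exchange of a bromine-bearing phenyl for a chlorine-bearing one gives no change at the digits printed from compound 3 to compound 4 (within the scatter) and thus extends the flat result to a fourth aryl group. Chloro in place of fluoro on an aromatic carbon, a change of the halogen alone, gives no change at the digits printed from compound 2 to compound 4 (within the scatter) and 4-chlorophenyl in place of 2-methoxyphenyl gives no change at the digits printed from compound 1 to compound 4 (within the scatter) on the same double-bonded chain carbon. No evidence on this result is available.

The compounds shown leave open whether any change at this place can lower the read-out. From the compounds shown here alone, an amine or a carboxylic acid on this phenyl, or a longer chain carrying it, remains untested here.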